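Acetyl to Hydrogen Repeated on a Second Core

The source may report more compounds than this note shows. Statements on the series, on what has been measured and on what is new or still open speak of the compounds shown alone.

Of the compounds shown here, three have been measured in a functional assay on M4Beu cells for cytotoxicity against M4Beu cell line (Homo sapiens), in the presence of a further agent that is not named here; a higher number here means that more compound is needed for the effect, a lower number that less compound is needed. Compound 1 `CC(=O)Nc1nc(OCc2ccccc2)c2ncn(C3O[C@H](O)[C@@H](O)[C@H]3O)c2n1` gives 200 uM, compound 2 `Nc1nc(OCc2ccccc2)c2ncn(C3O[C@H](O)[C@@H](O)[C@H]3O)c2n1` gives 244 uM, and compound 3 `CC(=O)Nc1nc(OCc2ccc(I)cc2)c2ncn(C3CC(O)C(O)O3)c2n1` gives 269 uM. The change hydrogen in place of acetyl on a nitrogen on an aromatic ring produced a 1.2-fold higher number from compound 1 to compound 2 (0.09 log units; within the scatter). Compound 4 `Nc1nc(OCc2ccc(I)cc2)c2ncn(C3CC(O)C(O)O3)c2n1` carries the same change, (hydrogen in place of acetyl on a nitrogen on an aromatic ring), on the core of compound 3; the place is described in the same words for both pairs, so it counts as the same change. How the core of compound 3 differs from that of compound 1 is not broken down here, and the two cores stand within the scatter of one another in this assay. The step is expected to be a 1.1-fold higher number from compound 3 to compound 4 (0.05 log units; within the scatter), because the identical change gave a 1.2-fold higher number from compound 1 to compound 2 (0.09 log units; within the scatter). Compound 4 is therefore estimated at 300 uM, expected between 150 uM and 600 uM.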

Compound 4, concentration for half-maximal effect: 4 uM
Estimate against measurement, compound 4: 75-fold (1.88 log units) above; measured number outside the range, below it.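

On the second core, the change of acetamido to amino gave a 67-fold lower number from compound 3 to compound 4 (1.83 log units; beyond the scatter), so in this assay this step cannot be treated as having a fixed size in this series. The step did not carry over from the first core to the second: the same change on two cores in this assay, a 1.2-fold higher number (0.09 log units; within the scatter) from compound 1 to compound 2 and a 67-fold lower number (1.83 log units; beyond the scatter) from compound 3 to compound 4, 82-fold (1.91 log units) apart, beyond the scatter of two such steps. This shows that the result on one core did not predict the result on the other, but it does not show which difference between the two cores goes with the gap, and two pairs establish no rule for other cores.

The compounds shown leave open how a longer acyl chain or a methyl group on that nitrogen would read on the core of compound 3. They also leave open whether other groups there would come close to compound 4 at 4 uM.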